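FXR Binding: Replacing the Distal Aryl With a Cinnamate

This account rests on a few compounds, and the source may have more. Where it says the series, first, only, none or still open, it means among the compounds named here.

Measured so far:
compound 1, `COC(=O)/C=C/c1cccc(N(Cc2ccc(-c3cccc(C)c3)cc2)C(=O)C2CCCCC2)c1`, 109 nM 
compound 2, `COC(=O)/C=C/c1cccc(N(Cc2ccc(-c3c(OC)cccc3OC)cc2)C(=O)C2CCCCC2)c1`, 77 nM 
compound 3, `COC(=O)/C=C/c1cccc(N(Cc2ccc(-c3ccc(C(C)(C)C)cc3)cc2)C(=O)C2CCCCC2)c1`, 132 nM 

In an assay on isolated protein with Bile acid receptor (Homo sapiens) as the target (on this read-out higher numbers stand for an effect only at larger amounts of compound and lower numbers for an effect already at smaller amounts), compound 3 gives the highest number of the three, but its steps to the other two are small: a 1.2-fold higher number from compound 1 to compound 3 (0.08 log units; within the scatter) and a 1.7-fold higher number from compound 2 to compound 3 (0.23 log units; within the scatter), both within the scatter. Compound 1 and compound 2 also sit close together, a 1.4-fold lower number from compound 1 to compound 2 (0.15 log units; within the scatter). Across these three compounds the variation of the distal aryl group leaves this assay essentially unchanged.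

Compound 4, `COC(=O)/C=C/c1ccc(CN(C(=O)C2CCCCC2)c2cccc(/C=C/C(=O)OC)c2)cc1`, goes a different way: 2-(methoxycarbonyl)ethenyl in place of 4-(tert-butyl)phenyl on an aromatic carbon. Within the data shown here, none of the measured steps covers this kind of exchange; the three measured steps only swap one aryl group for another and were all within the scatter. The distal aryl was tolerated in every form tried. Its complete removal in favour of a second 2-(methoxycarbonyl)ethenyl group is a step without precedent here, and the expectation is uncertain. Compound 4 is estimated to give a somewhat higher number than compound 3, with an expected step of a 2.0-fold higher number from compound 3 to compound 4 (0.29 log units; within the scatter). The estimate for compound 4 in this assay is 260 nM, with a range from 80 nM to 900 nM.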

Compound 4, half-maximal effective concentration: > 1000 nM
Compound 4 ended at the assay's limit (the forecaster's own chance of this, stated with the estimate: 10%); middle value at least 3.8-fold (0.58 log units) away from the limit.
By their numbers in this assay, from the lowest: compounds 2, 1 and 3 (each within the scatter of the next). At a limit, above all of these: compound 4.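

Where the three aryl groups stayed within the scatter of one another in this assay, 2-(methoxycarbonyl)ethenyl is the first exchange at this aromatic carbon to move the read-out beyond the scatter, with an at least 7.5-fold higher number from compound 3 to compound 4 (0.87 log units; beyond the scatter), an at least 12-fold higher number from compound 2 to compound 4 (1.11 log units; beyond the scatter) and an at least 9.1-fold higher number from compound 1 to compound 4 (0.96 log units; beyond the scatter). For compound 4, > 1000 nM is a limit of the assay and not a number, and the steps built on it give only a minimum size: the limit of > 1000 nM in this assay, at which 1 of the 4 values shown sits. The tolerance seen earlier therefore holds for 3-methylphenyl, 2,6-dimethoxyphenyl and 4-(tert-butyl)phenyl but not for every group at this carbon, and since this exchange both removes a six-membered aromatic ring of carbon only and brings in a methyl ester, the result cannot say which of the two changes counts.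

A plain phenyl, a saturated cyclohexyl or a pyridyl ring at this carbon would help to show whether an aromatic ring of carbon only is what the position requires. The corresponding carboxylic acid, a primary amide or a saturated propanoate ester chain would test the ester and the double bond of the 2-(methoxycarbonyl)ethenyl group apart from the loss of the ring.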